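Swapping the Ether Side Ring of Compound 2

This account rests on a few compounds, and the source may have more. Where it says the series, first, only, none or still open, it means among the compounds named here.

Compound 2 `Cc1cc(OC[C@@H]2CN(C)c3ccccc3O2)cc(C)c1C(=O)Nc1cc(CC(=O)O)ccc1Cl` was tested in an assay on CHO cells for displacement of a labelled ligand from prostacyclin receptor (Homo sapiens), read by scintillation counting, with a stated time of 30 min; a lower number here means a stronger inhibitor, a higher number a weaker inhibitor. In this assay compound 2 gives only a limit, > 10000 nM. Within the data shown here, its one measured neighbour, compound 1 `Cc1ccc(CC(=O)O)cc1NC(=O)c1c(C)cc(OC[C@@H]2CN(C)c3ccccc3O2)cc1C`, differs from it by a chloro in place of a methyl on an aromatic carbon. In this assay compound 1 also gives only a limit, > 10000 nM. The step from compound 1 to compound 2 is therefore a step that the two limits leave unreadable from compound 1 to compound 2, as the limit of > 10000 nM in this assay, at which 2 of the 2 values shown sit, shows. Compound 3 `Cc1cc(OC[C@@H]2COc3ccccc3O2)cc(C)c1C(=O)Nc1cc(CC(=O)O)ccc1Cl` follows from compound 2 by one change: a group of 10 heavy atoms (8 carbon, 2 oxygen; one six-membered non-aromatic ring with 2 hetero atoms, one six-membered aromatic ring of carbon only) in place of a group of 11 heavy atoms (9 carbon, 1 nitrogen, 1 oxygen; one six-membered non-aromatic ring with 2 hetero atoms, one six-membered aromatic ring of carbon only), on a saturated chain carbon bound to an oxygen on an aromatic ring. Among the measured compounds shown here, no measured step concerns this exchange, and the single measured step has no readable size, so nothing here points to a gain or a loss beyond the scatter. With compound 2 sitting at a limit, compound 3 is expected to remain weak, and the estimated step from compound 2 to compound 3 is a step that the limit leaves unreadable from compound 2 to compound 3. Compound 3 is estimated at 12000 nM, within 2500 nM to 50000 nM, with a real chance that only a limit is reported again.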

Compound 3, inhibition constant: > 10000 nM
Compound 3: no number, only a limit; the forecaster's own chance of this, stated with the estimate: 70%; the middle value lies beyond the limit too.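

In this assay compound 3 gives only a limit, > 10000 nM. The step from compound 2 to compound 3 therefore cannot be read: the limit of > 10000 nM in this assay, at which 3 of the 3 values shown sit. The compounds shown leave open how strong an inhibitor any of them is, and whether either exchange changes that at all.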